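The source may hold more compounds than are shown below. What is called first, only, known or untested is meant among the compounds shown, and "the series" means these compounds.

Of the compounds shown here, three sharing one core have been measured in a functional assay on HepG2 cells (Homo sapiens) for cytotoxicity, read by MTT assay; a lower number here means a stronger inhibitor, a higher number a weaker inhibitor. Compound 1 `Cc1nc2c(s1)C(=O)C=C(Nc1cccc(Br)c1)C2=O` gives 15 ug/mL, compound 2 `Cc1nc2c(s1)C(=O)C=C(Nc1cccc(Cl)c1)C2=O` gives 5.7 ug/mL, and compound 3 `CCOc1ccc(NC2=CC(=O)c3ncsc3C2=O)cc1` gives 23.6 ug/mL, the highest of the three numbers; its gap to compound 1 lies within the scatter, while its gap to compound 2 lies beyond it. Among the measured compounds shown here, the only single-point step recorded so far, a 2.6-fold lower number from compound 1 to compound 2 (0.42 log units; beyond the scatter), concerns the halogen and does not bear on the change now considered. Compound 4 `O=C1C=C(Nc2ccccc2)C(=O)c2scnc21` differs from compound 3 by hydrogen in place of ethoxy on an aromatic carbon. For the measured compounds named here, no measured step covers removal of an ethoxy group, so the direction is open; the step is expected to stay near the scatter, a 1.3-fold lower number from compound 3 to compound 4 (0.12 log units; within the scatter). Compound 4 is therefore expected to give 18 ug/mL in this assay, within a range from 8 ug/mL to 40 ug/mL.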

Compound 4, half-maximal inhibitory concentration: 14.7 ug/mL
For compound 4 the middle estimate is 1.2-fold (0.09 log units) above the measured one; low and high end bracket the measured number.
By their numbers in this assay, from the lowest: compound 2; then compounds 4, 1 and 3 (each within the scatter of the next).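

Hydrogen in place of ethoxy on the aromatic carbon para to a large group gives a 1.6-fold lower number from compound 3 to compound 4 (0.21 log units; within the scatter) in this assay. Among the compounds shown here, this is the first reading at this position, and it shows that the ethoxy group can be replaced by hydrogen without a change that stands clear of the scatter. No measured evidence on these groups bears on this result.

From the compounds shown here alone, whether an amine or a carboxylic acid here would give a step beyond the scatter remains open. So does the effect of a chain longer than ethoxy at this place.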